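Butyl to methoxy on the core of compound 2

This account rests on a few compounds, and the source may have more. Where it says the series, first, only, none or still open, it means among the compounds named here.

Working notes on a short series read in a functional assay on the whole organism with Rattus norvegicus as the target; on this read-out lower numbers stand for an effect already at smaller amounts and higher numbers for an effect only at larger amounts of compound. Compound 1 `CCCCc1c(OC)nc2nc(C(=O)c3ccccc3)cn2c1CC` gives 10 mg/kg. Compound 2 `CCCCc1c(OC)nc2nc(C(=O)c3ccccc3)cn2c1C` gives 2 mg/kg, the lowest of the three numbers; compound 3 `CCCc1cc(SC)nc2nc(C(=O)c3ccccc3)cn12` gives 10 mg/kg. Among the measured compounds shown here, the one step measured inside the series, a 5.0-fold lower number from compound 1 to compound 2 (0.70 log units; beyond the scatter), is the only change with a direct counterpart, and it sits on a saturated chain carbon, not on the ring.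

Compound 4 `COc1nc2nc(C(=O)c3ccccc3)cn2c(C)c1OC` is the next compound to be read in this assay. It differs from compound 2 as follows: methoxy in place of butyl on an aromatic carbon. For the measured compounds named here, no measured pair shows a change at that aromatic carbon, and compound 3 differs from compound 2 in more than one place, so its value cannot be read as a step for this change. The expectation therefore rests on little more than the position of compound 2 as the lowest number and the lack of any shown step for swapping butyl for methoxy on the ring.

A modest move to a higher number is expected, a 2.5-fold higher number from compound 2 to compound 4 (0.40 log units; beyond the scatter), with wide uncertainty in both directions. Compound 4 is estimated at 5 mg/kg, within a range from 1.5 mg/kg to 20 mg/kg.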

Compound 4, minimum effective dose: 5 mg/kg
Compound 4: middle estimate and measured number agree at the digits printed; low and high end bracket the measured number.
By their numbers in this assay, from the lowest: compound 2; then compounds 4, 1 and 3 (each within the scatter of the next).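

In this assay, among the compounds shown here, a 2.5-fold higher number from compound 2 to compound 4 (0.40 log units; beyond the scatter) is the first measured change at this aromatic carbon, where earlier the only step read sat on a saturated chain carbon. Butyl, with 4 heavy atoms and no hydrogen-bond acceptor, gives way to methoxy, with 2 heavy atoms and 1 hydrogen-bond acceptor, and compound 4 still gives a finite minimum effective dose of 5 mg/kg, so an effect in the whole organism does not depend on butyl at this position, although the swap carries a cost beyond the scatter. No available measurement speaks to the reason for this step.

The single swap changes chain length and brings in oxygen together, so the compounds shown leave open which of the two goes with the higher number. An ethoxy group would keep the oxygen with a longer chain, a propyl chain would keep an all-carbon substituent at a shorter length, and an amine on this aromatic carbon would test a different attached atom, so each would help separate these readings.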